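Hydroxy for hydroxymethyl on the pendant phenyl of compound 3

The source may report more compounds than this note shows. Statements on the series, on what has been measured and on what is new or still open speak of the compounds shown alone.

Going by the values given here, compound 3 `Nc1nc(-c2cccc(CO)c2)nc2sc(-c3ccco3)nc12` gives 28 nM in an assay on CHO cells for displacement of a labelled ligand from adenosine receptor A1 (Homo sapiens), read by scintillation counting, with a stated time of 3 h (a lower number here means a stronger inhibitor, a higher number a weaker inhibitor), the lowest of the three numbers measured so far. Compound 1 `Nc1nc(-c2cccc(CO)c2)nc2sc(-c3ccccc3)nc12` gives 32 nM in this assay, and the step of a 1.1-fold lower number from compound 1 to compound 3 (0.06 log units; within the scatter) sits within the scatter, so compound 3 and compound 1 cannot be ordered. Compound 2 `N#Cc1cccc(-c2nc(N)c3nc(-c4ccccc4)sc3n2)c1` gives 594 nM in this assay, and the step of a 19-fold higher number from compound 1 to compound 2 (1.27 log units; beyond the scatter) is the only large one seen.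

Compound 4 `Nc1nc(-c2cccc(O)c2)nc2sc(-c3ccco3)nc12` differs from compound 3 by hydroxy in place of hydroxymethyl on an aromatic carbon. Among the compounds with values here, the step from compound 1 to compound 2 bears on it, since it is the only change at this same position, and there the loss of the hydroxymethyl in favour of a nitrile cost much potency. The step from compound 1 to compound 3 concerns a different position and bears little. Within the data shown here, no measured pair tests a hydroxy at this site. Compound 4 is therefore expected to keep donor and acceptor but may lose some potency, giving an estimated 1.6-fold higher number from compound 3 to compound 4 (0.21 log units; within the scatter). Compound 4 is estimated at 45 nM, within 12 nM to 180 nM.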

Compound 4, inhibition constant: 51 nM
For compound 4 the middle estimate is 1.1-fold (0.05 log units) below the measured one, and the stated range covers the measured number.
By their numbers in this assay, from the lowest: compounds 3, 1 and 4 (each within the scatter of the next); then compound 2.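

In this assay hydroxy in place of hydroxymethyl gives a 1.8-fold higher number from compound 3 to compound 4 (0.26 log units; within the scatter) and so the two groups cannot be ordered at this position, even with the carbon of the hydroxymethyl gone. This is the first change shown at this position that stays within the scatter, in contrast to the nitrile change, a 19-fold higher number from compound 1 to compound 2 (1.27 log units; beyond the scatter), although that step was read with phenyl rather than furan-2-yl on the shared core. No measurement at hand accounts for the difference between these two steps.

From the compounds shown here alone, whether an amine, a carboxylic acid or a longer chain such as hydroxyethyl at this position would also stay within the scatter of compound 3 remains open. Also open, going by these compounds, is whether the hydroxy change reads the same with phenyl in place of furan-2-yl.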